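The source may hold more compounds than are shown below. What is called first, only, known or untested is meant among the compounds shown, and "the series" means these compounds.

Among the measured compounds shown here, in a physicochemical assay for lipophilicity (a higher number here means a more lipophilic compound, a lower number a more polar compound), compound 1 (`O=C1CN(Cc2ccc(-c3ccc(F)c(CN4CCCCC4)n3)cc2)C(=O)N1CC1CC1`) gives 2.8 and stands highest of the two numbers so far. Compound 2 (`CN1C(=O)CN(Cc2ccc(-c3cccc(CN4CCCCC4)n3)cc2)C1=O`) gives 1.3 as the lower number, a gap beyond the scatter. Compound 3 (`O=C1CN(Cc2ccc(-c3ccc(F)c(CN4CCCCC4)n3)cc2)C(=O)N1CC1CCC1`) differs from compound 1 in one place (cyclobutyl in place of cyclopropyl on a saturated chain carbon bound to an amide-type nitrogen in a ring). For the measured compounds named here, no measured pair isolates this change, so the expectation is only a small upward step in this assay, near the edge of the scatter. The estimated step runs a number 0.40 log units higher from compound 1 to compound 3 (beyond the scatter) as a working figure. Compound 3 is estimated at 3.2 (range 2.8 to 3.6).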

Compound 3, distribution coefficient: 3.5
Compound 3: the middle estimate sits 0.30 log units below what was measured; the measured number falls inside the stated range.
By their numbers in this assay, from the lowest: compound 2; then compound 1; then compound 3.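

Among the compounds shown here, on the saturated chain carbon bound to an amide-type nitrogen in a ring, cyclobutyl in place of cyclopropyl gives the only single-place comparison so far in this assay, a step of a number 0.70 log units higher from compound 1 to compound 3 (beyond the scatter). The change from a three-membered to a four-membered ring of carbon only, with the rest of compound 1 untouched, is thus enough to move the number beyond the scatter. Nothing at hand accounts for the size of this step. Still open, on these data alone, is whether an open chain such as butyl, or an oxygen-bearing ring such as oxetanyl, would shift the number at this place in the same direction.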